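The compounds below may be only part of what the source reports. "The series", "measured", "known", "first", "only" and "open" are said of these compounds alone.

Measured so far in a functional assay on U2OS cells (Homo sapiens) for antiproliferative activity, read by MTT assay, with a stated time of 72 h; a lower number here means a stronger inhibitor, a higher number a weaker inhibitor:

- compound 1, `O=C(CSc1cccc(O)c1)Nc1ccc2nc(NC(=O)c3cc(Cl)cc(Cl)c3)sc2c1`, gives 1530 nM.
- compound 2, `O=C(CSc1ccc2ccccc2c1)Nc1ccc2nc(NC(=O)c3ccc(C(F)(F)F)cc3)sc2c1`, gives 3940 nM.
- compound 3, `Cn1c(CNC(=O)c2cccs2)nnc1SCC(=O)Nc1cccc(Cl)c1`, returns only a limit, > 100000 nM, and no number.

Among the two numbered values, compound 1 stands lowest, and compound 2 sits above it by a gap that is beyond the usual scatter of repeated runs. Compound 3 is represented solely by the limit of > 100000 nM in this assay, at which 1 of the 3 values shown sits, so it offers no number to compare. Within the data shown here, no pair of these three differs in only one place, so no measured step is available to guide the next exchange.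

The next compound to be run is compound 4, `Cc1cc(C)cc(C(=O)Nc2nc3ccc(NC(=O)CSc4cccc(O)c4)cc3s2)c1`. Set against compound 1, the change reads (3,5-dimethylphenyl in place of 3,5-dichlorophenyl on a carbonyl carbon). The rest of the molecule, the shared core and its other substituents, is unchanged between the two. Among the measured compounds shown here, with no matched step in hand, the expectation in this assay is a small move, most likely within the scatter, with a lean toward a somewhat higher number rather than a lower one. Compound 4 is therefore expected near 2500 nM, with a plausible span from 800 nM to 8000 nM. The estimated step of a 1.6-fold higher number from compound 1 to compound 4 (0.21 log units; within the scatter) is expected to stay modest.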

Compound 4, half-maximal inhibitory concentration: 2820 nM
For compound 4 the middle estimate is 1.1-fold (0.05 log units) below the measured one, and the stated range covers the measured number.
By their numbers in this assay, from the lowest: compounds 1, 4 and 2 (each within the scatter of the next, the first and the last beyond it). At a limit, above all of these: compound 3.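

In this assay, among these compounds, the exchange on a carbonyl carbon, 3,5-dimethylphenyl in place of 3,5-dichlorophenyl, provides the first matched step, with a 1.8-fold higher number from compound 1 to compound 4 (0.27 log units; within the scatter) as its size and the rest of the molecule unchanged. This single pair therefore shows that the chlorine atoms are not required on this ring for antiproliferative activity in this range, since compound 1 and compound 4 cannot be told apart here. Among the compounds shown here, nothing measured so far bears on why the step has this size.

One matched pair, with both members carrying the same type of ring at this position, leaves the wider tolerance of the position undefined. As far as these compounds go, it remains open whether a nitrile, a methoxy group or an amine on this phenyl ring, or a cyclohexyl ring in place of the phenyl ring on the carbonyl carbon, would keep the value in this range or move it beyond the scatter.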